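Cytotoxicity notes: replacing the basic side chain of compound 1

The source may report more compounds than this note shows. Statements on the series, on what has been measured and on what is new or still open speak of the compounds shown alone.

Measured so far in a toxicity assay on L02 cells (Homo sapiens) for cytotoxicity, read by MTT assay, with a stated time of 72 h; a lower number here means a stronger inhibitor, a higher number a weaker inhibitor:
- compound 1 `CN(C)CCCCCn1c2c(c3ccccc31)C(=O)c1c[n+]([O-])c3ccccc3c1C2=O`: 240 nM
- compound 2 `O=C1c2c[n+]([O-])c3ccccc3c2C(=O)c2c1c1ccccc1n2CCCCn1ccnc1`: 150 nM
- compound 3 `CC1(C)OC[C@@H](Cn2cc(Cn3c4c(c5ccccc53)C(=O)c3c[n+]([O-])c5ccccc5c3C4=O)nn2)O1`: 2900 nM

Compound 1 stands second highest of the three numbers. Its nearest neighbour is compound 2, the step of a 1.6-fold lower number from compound 1 to compound 2 (0.20 log units; within the scatter) lying within the scatter; the furthest is compound 3, whose number is beyond the scatter above that of compound 1.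

The unmeasured compound 4 `O=C1c2c[n+]([O-])c3ccccc3c2C(=O)c2c1c1ccccc1n2Cc1cn(C[C@@H](O)CO)nn1` differs from compound 1 in the group carried by the saturated chain carbon bound to an aromatic nitrogen: 1-(2,3-dihydroxypropyl)-1H-1,2,3-triazol-4-yl in place of 4-(dimethylamino)butyl on a saturated chain carbon bound to an aromatic nitrogen.

Within the data shown here, only one measured step bears directly on this change, a 1.6-fold lower number from compound 1 to compound 2 (0.20 log units; within the scatter), and it is small. Compound 3, however, carries a triazole built from the same chain carbon and shares with compound 4 the chain and the ring, differing only in that its two oxygens are tied into a six-membered acetal; its number sits well above that of compound 1. Compound 3 is therefore the closer guide, and a clear upward step is expected for compound 4, estimated as a 7.5-fold higher number from compound 1 to compound 4 (0.88 log units; beyond the scatter) in this assay.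

Compound 4 is thus expected to give 1800 nM in this assay, with a likely range from 600 nM to 6000 nM.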

Compound 4, half-maximal inhibitory concentration: 490 nM
Compound 4: the middle estimate sits 3.7-fold (0.57 log units) above what was measured; measured number outside the range, below it.
By their numbers in this assay, from the lowest: compounds 2 and 1 (each within the scatter of the next); then compound 4; then compound 3.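

In this assay, a triazole on the saturated chain carbon bound to an aromatic nitrogen does not in itself give a number as high as that of compound 3: with 1,2-dihydroxyethyl in place of 2,2-dimethyl-1,3-dioxolan-4-yl, the change reads a 5.9-fold lower number from compound 3 to compound 4 (0.77 log units; beyond the scatter). Replacing the whole side chain with 1-(2,3-dihydroxypropyl)-1H-1,2,3-triazol-4-yl gives only modest steps, a 2.0-fold higher number from compound 1 to compound 4 (0.31 log units; beyond the scatter) and a 3.3-fold higher number from compound 2 to compound 4 (0.51 log units; beyond the scatter), so among these compounds neither a terminal dimethylamino group nor a terminal imidazole is needed for a number close to theirs. Nothing among the available data explains these steps.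

The compounds shown do not separate the contribution of the triazole from that of the diol; a triazole carrying a plain propyl group or a single 2-hydroxyethyl group would be the direct test. Also open, going by these compounds, are the mirror-image diol, with its stereocentre reversed, and whether a carboxylic acid at the end of the same side chain would stay near compound 4 in this assay.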